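The source may hold more compounds than are shown below. What is called first, only, known or untested is meant among the compounds shown, and "the series" means these compounds.

Compound 1 `O=C(N/N=C/c1ccc(Br)cc1)Nc1ccc(Oc2ccnc3[nH]ccc23)c(F)c1`: 920 nM
Compound 2 `O=C(N/N=C/c1ccccc1)Nc1ccc(Oc2ccnc3[nH]ccc23)cc1`: 10200 nM
Compound 3 `COc1ccc(/C=N/NC(=O)Nc2ccc(Oc3ccnc4[nH]ccc34)cc2)c(OC)c1OC`: 27600 nM

In a functional assay on PC-3 cells (Homo sapiens) for antiproliferative activity, read by MTT assay, with a stated time of 72 h (on this read-out higher numbers stand for weaker inhibition and lower numbers for stronger inhibition), compound 1 gives 920 nM, the lowest of the three numbers. Compound 2 gives 10200 nM and compound 3 gives 27600 nM, and both gaps to compound 1 lie beyond the usual scatter, so compound 1 stands as the strongest inhibitor among the measured compounds. Compound 4 `CN(C)CCn1cccc1/C=N/NC(=O)Nc1ccc(Oc2ccnc3[nH]ccc23)c(F)c1` has not yet been tested in this assay. It differs from compound 1 in a single place: 1-(2-(dimethylamino)ethyl)-1H-pyrrol-2-yl in place of 4-bromophenyl on a carbon with a double bond to nitrogen. Among the measured compounds shown here, no measured pair in this set differs by such a change, so the size of the step cannot be read from the data. A modest move toward weaker inhibition is expected, and the expected step is a 2.2-fold higher number from compound 1 to compound 4 (0.34 log units; beyond the scatter), small enough that it may fall within the scatter. Compound 4 is therefore estimated at 2000 nM, with a range from 400 nM to 12000 nM.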

Compound 4, half-maximal inhibitory concentration: 1600 nM
The estimate for compound 4 lay 1.3-fold (0.10 log units) above the measured number; measured number inside the range.
By their numbers in this assay, from the lowest: compounds 1 and 4 (each within the scatter of the next); then compound 2; then compound 3.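

In this assay, putting 1-(2-(dimethylamino)ethyl)-1H-pyrrol-2-yl in place of 4-bromophenyl on a carbon with a double bond to nitrogen gives a 1.7-fold higher number from compound 1 to compound 4 (0.24 log units; within the scatter). Among the compounds shown here, this is the first single-place step in the set, and it shows that this place can take a very different group without a change beyond the scatter: a six-membered aromatic ring of carbon only, bearing bromine, gives way to a five-membered aromatic ring with a hetero atom and a chain with hydrogen-bond acceptors. No measured property is available that would explain this outcome. Going by these compounds, it remains open how much of the result belongs to the ring and how much to the chain, for instance whether a 1-methyl-1H-pyrrol-2-yl group would behave alike. Also open, on these data alone, is what a morpholine in place of the dimethylamino group would do.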